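Swapping Trifluoromethyl for Chloro on a Diaryl Urea

This account rests on a few compounds, and the source may have more. Where it says the series, first, only, none or still open, it means among the compounds named here.

Among the measured compounds shown here, compound 2 `COc1cc2cc(Oc3ccc(NC(=O)Nc4ccc(Cl)c(C(F)(F)F)c4)cc3)c(C)nc2cc1OC` gives 2540 nM in a functional assay on CAKI-1 cells (Homo sapiens) for inhibition, read by sulforhodamine B assay, with a stated time of 48 h (a higher number here means a weaker inhibitor of growth, a lower number a stronger inhibitor of growth), the lower of the two numbers measured so far. For the measured compounds named here, its only neighbour, compound 1 `COc1cc2cc(Oc3ccc(NC(=O)Nc4cccc(C(F)(F)F)c4)cc3)c(C)nc2cc1OC`, gives 4290 nM in this assay, and the step of a 1.7-fold lower number from compound 1 to compound 2 (0.23 log units; within the scatter) lies within the scatter, so the two compounds cannot be told apart on these data. Compound 3 `COc1cc2cc(Oc3ccc(NC(=O)Nc4ccc(Cl)c(Cl)c4)cc3)c(C)nc2cc1OC` differs from compound 2 by chloro in place of trifluoromethyl on an aromatic carbon.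

Going by the values given here, only one measured step exists, and it is the one that brings in the chloro group: a 1.7-fold lower number from compound 1 to compound 2 (0.23 log units; within the scatter). Among the compounds with values here, that step bears on the present change only loosely, since here the chloro group replaces a trifluoromethyl group rather than a hydrogen, and no measured pair shows that exchange. Within the data shown here, the one step available stayed within the scatter. With nothing pointing to a larger shift, no change beyond the scatter is expected in this assay for compound 3. Compound 3 is therefore estimated at about 3200 nM, with a range from 1100 nM to 9500 nM. The expected step is a 1.3-fold higher number from compound 2 to compound 3 (0.10 log units; within the scatter), essentially flat.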

Compound 3, concentration for total growth inhibition: 6650 nM
Compound 3: middle estimate off by 2.1-fold (0.32 log units), on the low side, within the range that was stated.
By their numbers in this assay, from the lowest: compounds 2, 1 and 3 (each within the scatter of the next, the first and the last beyond it).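

In this assay, among the compounds shown here, the exchange of trifluoromethyl for chloro, on an aromatic carbon ortho to a chloro group and meta to a large group, gives the first measured step beyond the scatter (a 2.6-fold higher number from compound 2 to compound 3 (0.42 log units; beyond the scatter)). This modest step shows that, with the neighbouring chloro group in place, the readout responds to the group at this position, which the earlier hydrogen-to-chloro step could not show. The 3,4-dichlorophenyl and 3-(trifluoromethyl)phenyl groups, however, cannot be told apart on the amide-type nitrogen (a 1.6-fold higher number from compound 1 to compound 3 (0.19 log units; within the scatter)), and no measurement given here accounts for either result.

As far as these compounds go, what remains open is how far this position tolerates other groups, such as a nitrile, a methyl group or a dimethylamino group, and whether any of them would give a lower number than compound 2 in this assay. It is also open whether the trifluoromethyl-to-chloro step keeps its size without the neighbouring chloro group, since the compounds shown offer this exchange only in its presence.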